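The source may hold more compounds than are shown below. What is called first, only, known or untested is meant among the compounds shown, and "the series" means these compounds.

Compound 1 `COc1ncc(-c2ccc3nc(NC(=O)NCCN4CCCC4)nn3c2)cc1NS(=O)(=O)c1ccc(F)cc1` gives 230 nM in a functional assay on HCT-116 cells (Homo sapiens) for cytotoxicity, read by MTT assay, with a stated time of 72 h; on this read-out higher numbers stand for weaker inhibition and lower numbers for stronger inhibition.
Compound 2 `COc1ncc(-c2ccc3nc(NC(=O)N(C)C)nn3c2)cc1NS(=O)(=O)c1ccc(F)cc1` gives 760 nM in this assay.
Compound 3 `CNC(=O)Nc1nc2ccc(-c3cnc(OC)c(NS(=O)(=O)c4ccc(F)cc4)c3)cn2n1` gives 180 nM in this assay.

Compound 1 stands second highest of these three numbers in this assay. Its nearest neighbour is compound 3, with a 1.3-fold lower number from compound 1 to compound 3 (0.11 log units; within the scatter), while compound 2 lies furthest from it, with a 3.3-fold higher number from compound 1 to compound 2 (0.52 log units; beyond the scatter).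

Compound 4 `COc1ncc(-c2ccc3nc(NC(=O)NCCN(C)C)nn3c2)cc1NS(=O)(=O)c1ccc(F)cc1` has not yet been measured. It differs from compound 1 in one place: dimethylamino in place of pyrrolidin-1-yl on a saturated chain carbon, two bonds along the chain from an amide-type nitrogen

Among the compounds with values here, two measured steps bear on this change. The step of a 1.3-fold lower number from compound 1 to compound 3 (0.11 log units; within the scatter) shows that removing the whole (pyrrolidin-1-yl)methyl group from the chain, down to a plain methyl urea, leaves the number essentially unchanged. The step of a 3.3-fold higher number from compound 1 to compound 2 (0.52 log units; beyond the scatter) is larger, but it involves putting methyl in place of hydrogen on the amide-type nitrogen, a feature that compound 4 keeps intact. Since trading pyrrolidin-1-yl for dimethylamino at the end of the chain is a smaller change than its complete removal, no step beyond the scatter is expected in this assay.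

Compound 4 is therefore estimated at 250 nM, with a likely range of 120 nM to 520 nM, which means an expected step of a 1.1-fold higher number from compound 1 to compound 4 (0.04 log units; within the scatter).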

Compound 4, half-maximal inhibitory concentration: 220 nM
Compound 4: middle estimate off by 1.1-fold (0.06 log units), on the high side; the measured number falls inside the stated range.
By their numbers in this assay, from the lowest: compounds 3, 4 and 1 (each within the scatter of the next); then compound 2.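

In this assay, replacing the pyrrolidin-1-yl ring at the end of the chain with open dimethylamino makes no step beyond the scatter (a 1.0-fold lower number from compound 1 to compound 4 (0.02 log units; within the scatter)), so at this place the ring itself is not required to hold the number. The 2-(dimethylamino)ethyl chain also stays within the scatter of the plain methyl urea (a 1.2-fold higher number from compound 3 to compound 4 (0.09 log units; within the scatter)), while the change from the dimethylamino urea remains beyond the scatter (a 3.5-fold lower number from compound 2 to compound 4 (0.54 log units; beyond the scatter)), so compound 4 repeats the pattern already seen with compound 1. The compounds shown include no measurement that explains why the chain end can change in this way.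

These compounds leave open how far this tolerance extends: a morpholine ring, a piperidine ring or a carboxylic acid at the chain end could give a different picture. A longer chain between the amide-type nitrogen and the terminal amine is also untested here, so the result speaks only for the 2-(pyrrolidin-1-yl)ethyl and 2-(dimethylamino)ethyl chains.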